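Replacing the Styryl Arm of Compound 2

The source may report more compounds than this note shows. Statements on the series, on what has been measured and on what is new or still open speak of the compounds shown alone.

In a functional assay on L1210 cells (Mus musculus) (a higher number here means a weaker inhibitor, a lower number a stronger inhibitor), compound 1 `Cc1ccc(/C=C/C(=O)Oc2ccc(/C=C3\CCCC(CN(C)C)C3=O)cc2)cc1` gives 2430 nM and compound 2 `CN(C)CC1CCC/C(=C\c2ccc(OC(=O)/C=C/c3ccc(F)cc3)cc2)C1=O` gives 1840 nM (within the scatter of each other). Compound 3 `CN(C)CC1CCC/C(=C\c2ccc(OC(=O)c3ccccc3)cc2)C1=O` differs from compound 2 in one place: phenyl in place of 2-(4-fluorophenyl)ethenyl on a carbonyl carbon. Going by the values given here, the only measured step is a 1.3-fold lower number from compound 1 to compound 2 (0.12 log units; within the scatter) (fluoro in place of methyl on an aromatic carbon) and it removes no ethenyl, so it offers only weak guidance. The expected change is a 1.4-fold higher number from compound 2 to compound 3 (0.13 log units; within the scatter) (none beyond the scatter). For compound 3 the estimated value is 2500 nM (expected range 800 nM to 7500 nM).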

Compound 3, half-maximal inhibitory concentration: 23400 nM
For compound 3 the middle estimate is 9.4-fold (0.97 log units) below the measured one; the measured number lies above the stated range.
By their numbers in this assay, from the lowest: compounds 2 and 1 (each within the scatter of the next); then compound 3.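

In this assay, replacing the 2-(4-fluorophenyl)ethenyl arm on the carbonyl carbon with phenyl gives a 13-fold higher number from compound 2 to compound 3 (1.10 log units; beyond the scatter) and the matching replacement of 2-(4-methylphenyl)ethenyl gives a 9.6-fold higher number from compound 1 to compound 3 (0.98 log units; beyond the scatter). These are the first changes at this position shown to go beyond the scatter, as the swap of methyl for fluoro on the arm's ring did not. Nothing available explains the rise.

Phenyl removes the ethenyl and the ring substituent together, so the compounds shown do not separate the two. On these data alone, whether the ethenyl link itself matters, or only the arm's length, remains open, and a 2-phenylethyl or benzyl group on the same carbonyl carbon would bear on that.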